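The source may report more compounds than this note shows. Statements on the series, on what has been measured and on what is new or still open speak of the compounds shown alone.

Compound 1 `CN(C)CCn1cnnc1-c1cc(Oc2ccc(NC(=O)N/N=C/c3c(Cl)cccc3Cl)cc2F)ccn1`: 280 nM
Compound 2 `CN(C)CCn1cnnc1-c1cc(Oc2ccc(NC(=O)N/N=C/c3ccc(F)cc3Cl)cc2F)ccn1`: 510 nM

Both were tested in a functional assay on HT-29 cells (Homo sapiens) for cytotoxicity, read by MTT assay, with a stated time of 72 h; a lower number here means a stronger inhibitor, a higher number a weaker inhibitor. Compound 2 stands at the higher of the two numbers, with compound 1 nearest; the step of a 1.8-fold higher number from compound 1 to compound 2 (0.26 log units; within the scatter) lies within the scatter. Compound 3 `Cc1cc(/C=N/NC(=O)Nc2ccc(Oc3ccnc(-c4nncn4CCN(C)C)c3)c(F)c2)cc(C)c1O` carries 4-hydroxy-3,5-dimethylphenyl in place of 2-chloro-4-fluorophenyl on a carbon with a double bond to nitrogen. Going by the values given here, the only measured step, a 1.8-fold higher number from compound 1 to compound 2 (0.26 log units; within the scatter), also exchanged the group on that same carbon and barely moved the number, so a small shift in either direction, or none beyond the scatter, is expected. Compound 3 is therefore estimated at 600 nM, within 150 nM to 2500 nM. That estimate means an expected step of a 1.2-fold higher number from compound 2 to compound 3 (0.07 log units; within the scatter).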

Compound 3, half-maximal inhibitory concentration: 1220 nM
Compound 3: middle estimate off by 2.0-fold (0.31 log units), on the low side; the measured number falls inside the stated range.
By their numbers in this assay, from the lowest: compounds 1 and 2 (each within the scatter of the next); then compound 3.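

With 4-hydroxy-3,5-dimethylphenyl on the carbon with a double bond to nitrogen, the exchange brings a 2.4-fold higher number from compound 2 to compound 3 (0.38 log units; beyond the scatter) and a 4.4-fold higher number from compound 1 to compound 3 (0.64 log units; beyond the scatter) and so shows that this position can move the number beyond the scatter. Both steps are modest, and this group, which carries no halogen, still leaves a measurable cytotoxic effect. Nothing measured here tells why the number rises.

Whether the hydroxy group or the two methyl groups account for the step remains open. So does how a phenyl ring bearing an amine or a carboxylic acid would behave on this carbon.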